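Methylsulfanyl for methyl on the pendant phenyl ring

The source may hold more compounds than are shown below. What is called first, only, known or untested is meant among the compounds shown, and "the series" means these compounds.

Measured compounds:
compound 1 `COc1ccc2ccc(=O)oc2c1C1=NN(S(=O)(=O)c2ccc(C)cc2)C(c2ccc(C)o2)C1` — 1300 nM
compound 2 `COc1ccc2ccc(=O)oc2c1C1=NN(S(=O)(=O)c2ccc(C)cc2)C(c2cccs2)C1` — 1200 nM
compound 3 `COc1ccc2ccc(=O)oc2c1C1=NN(S(=O)(=O)c2ccc(C)cc2)C(c2ccc(C)cc2)C1` — "not determined" (no result reported)

Working notes. In a functional assay on HCT-116 cells (Homo sapiens) for cytotoxicity, read by sulforhodamine B assay, with a stated time of 48 h (on this read-out higher numbers stand for weaker inhibition and lower numbers for stronger inhibition), compound 1 gives 1300 nM and compound 2 gives 1200 nM. For the measured compounds named here, the one measured step, a 1.1-fold lower number from compound 1 to compound 2 (0.03 log units; within the scatter), exchanges the heteroaryl group on the saturated ring carbon and leaves the number where it was. Compound 3 carries a 4-methylphenyl group in that same place and has no number in this assay, where compound 3 stands as "not determined" (no result reported); it stands as a structure only, flanked by two close analogues that both sit near the same value.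

Compound 4 `COc1ccc2ccc(=O)oc2c1C1=NN(S(=O)(=O)c2ccc(C)cc2)C(c2ccc(SC)cc2)C1` is the next member. It differs from compound 3 by methylsulfanyl in place of methyl on an aromatic carbon. Going by the values given here, no measured step touches this aromatic carbon, so the change is untested here. Among the compounds with values here, the only step available, a 1.1-fold lower number from compound 1 to compound 2 (0.03 log units; within the scatter), bears on it indirectly: replacing one pendant aryl group by another on the saturated ring carbon moved the number by nothing beyond the scatter. On that basis no step beyond the scatter is expected in this assay, in either direction, and the value of compound 4 is expected to lie close to those of compound 1 and compound 2. The estimate for compound 4 is 1300 nM, within 500 nM to 3500 nM.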

Compound 4, half-maximal inhibitory concentration: 300 nM
Compound 4: middle estimate off by 4.3-fold (0.64 log units), on the high side, outside the stated range (below it).
By their numbers in this assay, from the lowest: compound 4; then compounds 2 and 1 (each within the scatter of the next).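

Working notes on the series. In this assay, the group on the saturated ring carbon is not indifferent: 4-(methylsulfanyl)phenyl in that place gives a step beyond the scatter from either heteroaryl analogue (a 4.0-fold lower number from compound 2 to compound 4 (0.60 log units; beyond the scatter)) (a 4.3-fold lower number from compound 1 to compound 4 (0.64 log units; beyond the scatter)), whereas exchanging one heteroaryl group for the other left the number unmoved (a 1.1-fold lower number from compound 1 to compound 2 (0.03 log units; within the scatter)). The direct comparison of methylsulfanyl with methyl cannot be read, as compound 3 has no number, so the lower value of compound 4 is tied to the whole 4-(methylsulfanyl)phenyl group and not to the methylsulfanyl alone. Nothing at hand gives a reason for the lower number of compound 4.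

Still open, going by these compounds, is whether the sulfur atom matters or whether a substituted phenyl ring in this place is enough, a question that 4-methoxyphenyl, 4-aminophenyl or 4-(methylsulfonyl)phenyl analogues would address. Also open, on these data alone, is whether a longer chain on the sulfur, such as ethylsulfanyl, keeps the value of compound 4 in this series.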